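The source may report more compounds than this note shows. Statements on the series, on what has been measured and on what is new or still open speak of the compounds shown alone.

Of the compounds shown here, three share one core and have been measured. Compound 1 `O=[N+]([O-])c1ccc(N/C(=N\O)c2ccccc2)c2nonc12` gives 268 nM in an assay on isolated protein for inhibition of Indoleamine 2,3-dioxygenase 1 (Homo sapiens), read by spectrophotometry, with a stated time of 1 h; on this read-out higher numbers stand for weaker inhibition and lower numbers for stronger inhibition. Compound 2 `O=[N+]([O-])c1ccc(N/C(=N\O)c2cccc(Cl)c2)c2nonc12` gives 184 nM, and compound 3 `O=[N+]([O-])c1ccc(N/C(=N\O)c2ccc(F)cc2)c2nonc12` gives 100 nM. Compound 3 holds the lowest of the three numbers: its gap to compound 2 lies within the scatter, while a 2.7-fold lower number from compound 1 to compound 3 (0.43 log units; beyond the scatter). Compound 4 `O=[N+]([O-])c1ccc(N/C(=N\O)c2ccc(Br)cc2)c2nonc12` differs from compound 3 in one place: bromo in place of fluoro on an aromatic carbon. Among the compounds with values here, two measured steps bear on this change. The step of a 2.7-fold lower number from compound 1 to compound 3 (0.43 log units; beyond the scatter) shows that a fluoro in place of hydrogen on an aromatic carbon gave a modest improvement, whereas a 1.5-fold lower number from compound 1 to compound 2 (0.16 log units; within the scatter) shows that a chloro in place of hydrogen on the same ring stayed within the scatter. Within the data shown here, no measured step here swaps one halogen for another, so the data give no direct reading of the size of a fluoro-to-bromo exchange. The chemist therefore expects in this assay a step no larger than the scatter, in either direction: a 1.1-fold lower number from compound 3 to compound 4 (0.02 log units; within the scatter). The estimate for compound 4 is 95 nM, with a range from 40 nM to 230 nM.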

Compound 4, half-maximal inhibitory concentration: 117 nM
The estimate for compound 4 lay 1.2-fold (0.09 log units) below the measured number; low and high end bracket the measured number.
By their numbers in this assay, from the lowest: compounds 3, 4, 2 and 1 (each within the scatter of the next, the first and the last beyond it).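

Within the data shown here, the first direct exchange of one halogen for another at this place, on an aromatic carbon para to a large group, gives a 1.2-fold higher number from compound 3 to compound 4 (0.07 log units; within the scatter) in this assay, so fluoro and bromo cannot be told apart here. Bromo in place of hydrogen gives a 2.3-fold lower number from compound 1 to compound 4 (0.36 log units; beyond the scatter), so both fluoro and bromo at this place now stand beyond the scatter from the unsubstituted phenyl, whereas a 1.6-fold lower number from compound 2 to compound 4 (0.20 log units; within the scatter) leaves 4-bromophenyl unseparated from 3-chlorophenyl. No supporting data are available to explain these results.

The compounds shown carry only hydrogen or a halogen on this ring, so it remains open whether a methoxy group, an amine or a carboxylic acid at this place would keep the number as low. They also leave open how far this result carries to the 3-chlorophenyl position.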